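Methyl on a double-bonded ring carbon of compound 3

The source may hold more compounds than are shown below. What is called first, only, known or untested is meant among the compounds shown, and "the series" means these compounds.

Going by these compounds, the measured set holds compound 1 `COCC1=C[C@@](C)(c2cc(NC(=O)c3ccc(C#N)cn3)ccc2F)N=C(N)O1`, compound 2 `CC1=C[C@@](C)(c2cc(NC(=O)c3ccc(C#N)cn3)ccc2F)N=C(N)O1` and compound 3 `C[C@@]1(c2cc(NC(=O)c3ccc(C#N)cn3)ccc2F)C=COC(N)=N1`, while compound 4 `CC1=COC(N)=N[C@]1(C)c1cc(NC(=O)c2ccc(C#N)cn2)ccc1F` remains open. In a physicochemical assay for acid dissociation, read by capillary electrophoresis, compound 1 gives 7.4, compound 2 gives 7.9 and compound 3 gives 7.7. Compound 3 stands within the scatter of both others, as the readings show a number 0.20 log units lower from compound 2 to compound 3 (within the scatter) and a number 0.30 log units higher from compound 1 to compound 3 (within the scatter). Among the measured compounds shown here, only one measured step clears the scatter: a number 0.50 log units higher from compound 1 to compound 2 (beyond the scatter).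

The change to compound 4 is methyl in place of hydrogen on a double-bonded ring carbon. The nearest measured precedent is the same exchange read in reverse, a number 0.20 log units lower from compound 2 to compound 3 (within the scatter), though compound 2 carries its methyl on a different double-bonded ring carbon, so the comparison is only partial. Replacing methoxymethyl with hydrogen on a double-bonded ring carbon gives a step of similar standing, a number 0.30 log units higher from compound 1 to compound 3 (within the scatter). For the measured compounds named here, neither precedent points to a change beyond the scatter, and no measured compound carries a substituent at the position changed in compound 4. The expected step is a number 0.10 log units higher from compound 3 to compound 4 (within the scatter), with no shift beyond the scatter anticipated in this assay. Compound 4 is estimated at 7.8, with an expected range of 7.4 to 8.2.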

Compound 4, acid dissociation constant: 8
Beside the measured number, compound 4's estimate is 0.20 log units below it; the measured number falls inside the stated range.
By their numbers in this assay, from the lowest: compounds 1, 3, 2 and 4 (each within the scatter of the next, the first and the last beyond it).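

In this assay, among the compounds shown here, this is the first reading of a substituent on this double-bonded ring carbon, next to the ring atom that bears a large group and next to the ring atom that bears a methyl group: methyl in place of hydrogen gives a number 0.30 log units higher from compound 3 to compound 4 (within the scatter), so the change stays inside the scatter on this pair. The exchange on an aromatic carbon of one group of 9 heavy atoms for another of the same count gives a number 0.10 log units higher from compound 2 to compound 4 (within the scatter), and this read-out therefore does not separate compound 2 from compound 4. Nothing available on these compounds accounts for either step, and no cause can be assigned to them.

The compounds shown leave open whether a group other than methyl on this carbon, such as ethyl, trifluoromethyl or a single fluorine atom, would shift the reading from that of compound 3 beyond the scatter. Going by these compounds, the methyl step also rests on one pair, so it remains open whether it would read the same on a core carrying an amine in place of the nitrile.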